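The compounds below may be only part of what the source reports. "The series", "measured", "known", "first", "only" and "open" are said of these compounds alone.

Compound 1 `Cc1ncnc2c1c(-c1cccs1)cn2[C@@H]1O[C@H](CO)[C@@H](O)[C@H]1O`: > 15000 nM, a limit
Compound 2 `C#Cc1cn([C@@H]2O[C@H](CO)[C@@H](O)[C@H]2O)c2ncnc(C)c12`: 14700 nM
Compound 3 `Nc1nc(N)c2c(-c3cccs3)cn([C@@H]3O[C@H](CO)[C@@H](O)[C@H]3O)c2n1`: > 20000 nM, a limit

All three compounds were tested in a functional assay on HeLa S3 cells (Homo sapiens) for antiproliferative activity, read by XTT assay, with a stated time of 72 h; a lower number here means a stronger inhibitor, a higher number a weaker inhibitor. Compound 3 gave no exact number in this assay, only the limit of > 20000 nM.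

Compound 4 `Nc1nc(N)c2c(-c3cc4ccccc4o3)cn([C@@H]3O[C@H](CO)[C@@H](O)[C@H]3O)c2n1` keeps the core of compound 3 and changes one group: 1-benzofuran-2-yl in place of thiophen-2-yl on an aromatic carbon. In words, 1-benzofuran-2-yl stands in place of thiophen-2-yl on an aromatic carbon.

Within the data shown here, only one measured step removes thiophen-2-yl: an at least 1.0-fold lower number from compound 1 to compound 2 (0.00 log units; that floor lies within the scatter). That step offers limited guidance. It starts from a limit, its core is not the one shared by the later pair, and its incoming group is ethynyl. Among the measured compounds shown here, no measured compound carries 1-benzofuran-2-yl, so the direction of the new change cannot be read from these data.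

The cautious expectation is therefore no step beyond the usual scatter, with the new compound remaining weak in this assay. The estimated step is a number no higher from compound 3 to compound 4 (the limit leaves the size open), and a report of only a limit would be no surprise. For compound 4 the expected value is 20000 nM, with an estimated range from 7000 nM to 40000 nM.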

Compound 4, half-maximal inhibitory concentration: > 20000 nM
Compound 4 gave a limit, no number; the forecaster's own chance of this, stated with the estimate: 75%; the middle value sits exactly at the limit.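

In this assay compound 4 gave > 20000 nM, which is a limit and not a number. Compound 3 also stands only as a limit, so no step can be read between compound 3 and compound 4. The compounds shown leave open whether 1-benzofuran-2-yl or thiophen-2-yl gives the lower number on this core.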